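A Cyclohexyl Group on Compound 1

The source may report more compounds than this note shows. Statements on the series, on what has been measured and on what is new or still open speak of the compounds shown alone.

Values so far in an ADME assay on MT4 cells (Homo sapiens) for cytotoxicity, read by MTT assay, with a stated time of 96 h (a higher number here means that more compound is tolerated, a lower number that less compound is tolerated), are these.
Compound 1 (`COc1ccc(-c2nc3cc(/C(C)=N/NC(N)=S)ccc3[nH]2)cc1`): (5000 nM)
Compound 2 (`COc1ccc(-c2nc3cc(/C(C)=N/NC(N)=S)ccc3[nH]2)c(OC)c1`): (72000 nM)

Going by the values given here, of these two, compound 1 stands lowest, and compound 2 is its only neighbour. Compound 3 (`COc1ccc(-c2nc3cc(/C(C)=N/NC(N)=S)ccc3n2C2CCCCC2)cc1`) has not yet been measured. It differs from compound 1 by cyclohexyl in place of hydrogen on an aromatic nitrogen and carries cyclohexyl in place of hydrogen on an aromatic nitrogen. Among the compounds with values here, the only measured step, a 14-fold higher number from compound 1 to compound 2 (1.16 log units; beyond the scatter), is large, but it is methoxy in place of hydrogen on an aromatic carbon. That step shows how far one substitution can move the number, yet it gives no direction for this different change. Within the data shown here, no measured compound carries a group on that nitrogen. Only a small rise is therefore expected, a 1.6-fold higher number from compound 1 to compound 3 (0.20 log units; within the scatter), and no step beyond the scatter. Compound 3 is estimated at 8000 nM (expected range 2000 nM to 40000 nM).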

Compound 3, half-maximal cytotoxic concentration: 39000 nM
Estimate against measurement, compound 3: 4.9-fold (0.69 log units) below; low and high end bracket the measured number.
By their numbers in this assay, from the lowest: compound 1; then compounds 3 and 2 (each within the scatter of the next).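

In this assay, going by these compounds alone, cyclohexyl in place of hydrogen on the aromatic nitrogen gives a 7.8-fold higher number from compound 1 to compound 3 (0.89 log units; beyond the scatter), so a group on this nitrogen, which no earlier compound carried, moves the number beyond the scatter. This is the second single change to compound 1 that raises the number, and it lies at a different place from the methoxy change behind a 14-fold higher number from compound 1 to compound 2 (1.16 log units; beyond the scatter). Nothing available explains the rise seen with cyclohexyl.

The compounds shown leave open whether the rise belongs to cyclohexyl itself or would also appear with a methyl, a benzyl or a longer chain on that nitrogen. They also leave open what the cyclohexyl and the added methoxy would do together in one compound.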